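Chloro for fluoro on the anilide ring of compound 3

The source may hold more compounds than are shown below. What is called first, only, known or untested is meant among the compounds shown, and "the series" means these compounds.

Compound 1 `O=C(CSc1nc(Nc2ccccc2)c2ccccc2n1)Nc1ccccc1F` gives > 50000 nM in a functional assay on MDA-MB-231 cells (Homo sapiens) for inhibition, read by MTT assay, with a stated time of 72 h (on this read-out lower numbers stand for stronger inhibition and higher numbers for weaker inhibition), a limit of the assay.
Compound 2 `O=C(CSc1nc(Nc2ccccc2)c2ccccc2n1)Nc1ccccc1Br` gives 14100 nM.
Compound 3 `O=C(CSc1nc(Nc2ccccc2)c2ccccc2n1)Nc1cccc(F)c1` gives > 50000 nM, again a limit of the assay.

Compound 3 therefore sits at the assay's limit, where (the limit of > 50000 nM in this assay, at which 2 of the 3 values shown sit), and no number is known for it. Its neighbour compound 2 stands an at least 3.5-fold higher number from compound 2 to compound 3 (0.54 log units; beyond the scatter). Compound 4 `O=C(CSc1nc(Nc2ccccc2)c2ccccc2n1)Nc1cccc(Cl)c1` differs from compound 3 by chloro in place of fluoro on an aromatic carbon. Among the compounds with values here, the one measured step of the same kind, in which only the halogen is exchanged, runs an at least 3.5-fold lower number from compound 1 to compound 2 (0.54 log units; beyond the scatter), though there the ring was 2-bromophenyl rather than 3-chlorophenyl. The step that the two limits leave unreadable from compound 1 to compound 3 gives no size. On that thin basis a modest lowering of the number from compound 3 to compound 4 is expected, around an at least 2.0-fold lower number from compound 3 to compound 4 (0.30 log units; that floor lies within the scatter), with a real chance that compound 4 again only reaches the limit. Compound 4 is estimated at 25000 nM, within 8000 nM to 60000 nM.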

Compound 4, half-maximal inhibitory concentration: 16500 nM
The estimate for compound 4 lay 1.5-fold (0.18 log units) above the measured number; low and high end bracket the measured number.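

Exchanging fluoro for chloro meta to a large group gives, in this assay, an at least 3.0-fold lower number from compound 3 to compound 4 (0.48 log units; beyond the scatter), so a halogen exchange lowers the number on the 3-substituted ring as well as on the 2-substituted one. Against the 2-bromophenyl anilide, the result is a 1.2-fold higher number from compound 2 to compound 4 (0.07 log units; within the scatter), and against the 2-fluorophenyl anilide it is an at least 3.0-fold lower number from compound 1 to compound 4 (0.48 log units; beyond the scatter), so the two heavier-halogen compounds cannot be told apart while both fluoro compounds stay apart from them. The steps out of the fluoro compounds are floors only, because those compounds sit at the limit: the limit of > 50000 nM in this assay, at which 2 of the 4 values shown sit.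

The compounds shown leave open how a bromo, methyl or trifluoromethyl group would read on this same ring position. They also leave open how a 2-chlorophenyl ring would compare with the 3-chlorophenyl ring of compound 4.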